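A few compounds are considered here, and "the series" means these few. Any claim that something is new, unique, unknown or untested is made for them only; others in the source may bear on it.

Compound 2 `CCOC(=O)C1=C(Nc2ccccc2)S/C(=C\c2ccc(Br)c(O)c2)C1=O` is the anchor of this step. In a functional assay on MCF7 cells (Homo sapiens) for inhibition, read by MTT assay, with a stated time of 72 h, tested at 10 uM (a higher number here means more inhibition at the concentration tested (going by the name of the read-out), a lower number less inhibition), compound 2 gives 16.4%. Compound 1 `CCOC(=O)C1=C(Nc2ccccc2)S/C(=C\c2ccc([N+](=O)[O-])c(O)c2)C1=O` carries a nitro where compound 2 carries a bromo, and in this assay compound 1 gives 41.5%; the step between them is a number 25.1 percentage points lower from compound 1 to compound 2 (beyond the scatter). Compound 3 `CCOC(=O)C1=C(Nc2ccc(OC)cc2)S/C(=C\c2ccc[nH]2)C1=O` differs from both in more than one place. In this assay compound 3 reaches only < 10%, which is a limit of the assay rather than a number, as recorded in the limit of < 10% in this assay, at which 1 of the 3 values shown sits. Of the two numbers shown, compound 2 therefore stands lowest, with compound 1 above it beyond the scatter, and one further value known only as a limit.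

Compound 4 `CCOC(=O)C1=C(Nc2ccccc2)S/C(=C\c2cc3ncccc3[nH]2)C1=O` has not been measured. Its change from compound 2 is a group of 9 heavy atoms (7 carbon, 2 nitrogen; one five-membered aromatic ring with 1 hetero atom, one six-membered aromatic ring with 1 hetero atom) in place of a group of 8 heavy atoms (6 carbon, 1 oxygen, 1 bromine; one six-membered aromatic ring of carbon only), on a double-bonded chain carbon bound to a double-bonded ring carbon. For the measured compounds named here, the only single-place step known, that from compound 1 to compound 2, exchanged one group on the six-membered aromatic ring of carbon only, whereas the present change replaces that whole ring with the entering group; no measured step covers it directly. Compound 3, which also carries a five-membered aromatic ring with one hetero atom, sits at the limit. The expectation for compound 4 in this assay is therefore a low number or a limit, with the step of a number 2.4 percentage points lower from compound 2 to compound 4 (within the scatter) expected to lie within the scatter or modestly downward. Compound 4 is estimated at 14%, in a range from 4% to 32%.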

Compound 4, a percentage reported as inhibition, at one concentration (the size of the read-out at that concentration, not a potency): 42.2%
Compound 4: middle estimate off by 28.2 percentage points, on the low side, outside the stated range (above it).
By their numbers in this assay, from the lowest: compound 2; then compounds 1 and 4 (each within the scatter of the next). At a limit, below all of these: compound 3.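

For the compounds shown here, at the double-bonded chain carbon bound to the double-bonded ring carbon, the earlier compounds showed only an exchange of one group on the six-membered aromatic ring of carbon only; in this assay, replacing the whole 4-bromo-3-hydroxyphenyl gives a number 25.8 percentage points higher from compound 2 to compound 4 (beyond the scatter). This place therefore accepts a fused pair of aromatic rings, a five-membered and a six-membered one with one hetero atom each, and that ring of carbon only is not needed for a reading of this size in the compounds shown. Compound 3 also carries a five-membered aromatic ring with one hetero atom at this place, but it differs from compound 4 in more than one place, and its value is a limit, so it gives no step to set beside this one: the limit of < 10% in this assay, at which 1 of the 4 values shown sits.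

Which part of the entering group carries the step stays open, as a plain phenyl, an indole with no nitrogen in its six-membered ring, or a single pyrrole on the anilino core would be needed to separate the two rings. Also open, on these data alone, is whether the step holds with an amine or a carboxylic acid on the fused rings, and, since the read-out is taken at one concentration, how it would appear as a potency.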